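The source may report more compounds than this note shows. Statements on the series, on what has been measured and on what is new or still open speak of the compounds shown alone.

In a functional assay on MGC-803 cells (Homo sapiens) for inhibition, read by MTT assay (a lower number here means a stronger inhibitor, a higher number a weaker inhibitor), compound 1 `Cc1c(C(=O)N/N=C\c2ccccc2O)oc2cccc(O)c12` gives 10600 nM, and compound 2 `Cc1c(C(=O)N/N=C\c2cc(F)ccc2O)oc2cccc(O)c12` gives 5230 nM. Going by the values given here, compound 2 holds the lower of the two numbers so far, and the one step that links them, a 2.0-fold lower number from compound 1 to compound 2 (0.31 log units; beyond the scatter), is the only comparison available. Compound 3 `Cc1c(C(=O)N/N=C\c2cccc(Br)c2O)oc2cccc(O)c12` differs from compound 2 by 3-bromo-2-hydroxyphenyl in place of 5-fluoro-2-hydroxyphenyl on a carbon with a double bond to nitrogen. Among the compounds with values here, no measured step matches this exchange of one halogen-bearing ring for another; the single step from compound 1 to compound 2 shows only that adding a halogen to this ring moved the number modestly. On that slim basis a change of similar size in this assay, or none beyond the scatter, is expected, with no clear direction. The estimate for compound 3 in this assay is therefore 5000 nM, within a range from 2000 nM to 14000 nM, which corresponds to an expected step of a 1.0-fold lower number from compound 2 to compound 3 (0.02 log units; within the scatter).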

Compound 3, half-maximal inhibitory concentration: 14200 nM
Estimate against measurement, compound 3: 2.8-fold (0.45 log units) below; measured number above the stated range.
By their numbers in this assay, from the lowest: compound 2; then compounds 1 and 3 (each within the scatter of the next).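

In this assay, the gain seen with fluoro does not carry over to every halogen on this ring: a 2.7-fold higher number from compound 2 to compound 3 (0.43 log units; beyond the scatter) comes with 3-bromo-2-hydroxyphenyl in place of 5-fluoro-2-hydroxyphenyl. Bromo in place of hydrogen gives a 1.3-fold higher number from compound 1 to compound 3 (0.13 log units; within the scatter) and so leaves the number where it was, which shows that placing a halogen on this ring does not by itself lower the number. No measurement at hand explains this difference between the two halogen-bearing rings.

The exchange alters both the halogen and its place on the ring, and separating the two would take a pair such as 5-bromo-2-hydroxyphenyl and 3-fluoro-2-hydroxyphenyl. On these data alone, how a group other than a halogen, such as methoxy or an amine, would behave on this ring also stays open.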